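From ethoxycarbonyl to hydroxymethyl at the assay's limit

The compounds below may be only part of what the source reports. "The series", "measured", "known", "first", "only" and "open" are said of these compounds alone.

Compound 2 `CCOC(=O)c1c(C)oc2ncnc(Nc3cccc(Br)c3)c12` gives only a limit in a functional assay on MCF7 cells (Homo sapiens) for cytotoxicity, read by MTT assay, with a stated time of 72 h (on this read-out lower numbers stand for stronger inhibition and higher numbers for weaker inhibition), namely > 1000000 nM. Compound 3 `CCOC(=O)c1c(C)oc2ncnc(Nc3cccc(OC)c3)c12`, with methoxy in place of bromo, is also reported only as a limit, > 1000000 nM. That leaves a step that the two limits leave unreadable from compound 2 to compound 3, so this change offers no guide. With hydrogen in place of the ethyl group, compound 1 `Cc1oc2ncnc(Nc3cccc(Br)c3)c2c1C(=O)O` gives a real number in this assay, 68000 nM. Within the data shown here, the one readable step is therefore an at least 14-fold higher number from compound 1 to compound 2 (1.16 log units; beyond the scatter), and it is large.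

Compound 4 `Cc1oc2ncnc(Nc3cccc(Br)c3)c2c1CO` changes the same part of compound 2: hydroxymethyl in place of ethoxycarbonyl on an aromatic carbon. Like compound 1, compound 4 has no ethyl group, but it also has no carbonyl, so the match is only partial. The large step seen in an at least 14-fold higher number from compound 1 to compound 2 (1.16 log units; beyond the scatter), read in reverse, points towards a lower number, probably by less than the full size of that step. The expected change is an at least 5.0-fold lower number from compound 2 to compound 4 (0.69 log units; beyond the scatter). For compound 4 the estimated value is 200000 nM, with an expected range from 50000 nM to 800000 nM.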

Compound 4, half-maximal inhibitory concentration: 11000 nM
Beside the measured number, compound 4's estimate is 18-fold (1.26 log units) above it; the measured number lies below the stated range.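

In this assay, hydroxymethyl in place of ethoxycarbonyl gives an at least 90-fold lower number from compound 2 to compound 4 (1.95 log units; beyond the scatter). Hydroxymethyl in place of carboxy gives a 6.2-fold lower number from compound 1 to compound 4 (0.79 log units; beyond the scatter), so a readable number at this position does not depend on a carbonyl group, something the earlier compounds could not show. Compound 2 is reported only as a limit, so the full size of its step stays unknown: the limit of > 1000000 nM in this assay, at which 2 of the 4 values shown sit.

Going by these compounds, whether the hydroxyl hydrogen itself matters stays open, and a methoxymethyl group or an aminomethyl group at this position would help to separate that question from the loss of the carbonyl. Among these compounds, also open is whether the bromo group counts once hydroxymethyl is in place; the only swap of bromo for methoxy joins two limits and cannot be read.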